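This account rests on a few compounds, and the source may have more. Where it says the series, first, only, none or still open, it means among the compounds named here.

Measured compounds:
compound 1 `Nc1cc(N)c2nc(-c3ccccc3)c(Sc3ccc(F)cc3)nc2c1`: 28200 nM
compound 2 `COc1cc(CNc2nc3cc(N)cc(N)c3nc2-c2ccccc2)cc(OC)c1OC`: 692 nM
compound 3 `CCOC(=O)[C@H](CCC(=O)O)NC(=O)c1ccc(Oc2nc3cc(N)cc(N)c3nc2-c2ccccc2)cc1`: < 100000 nM (a limit)

In a functional assay on RPMI8266 cells (Homo sapiens) for inhibition, read by sulforhodamine B assay, with a stated time of 48 h (a lower number here means a stronger inhibitor of growth, a higher number a weaker inhibitor of growth), compound 1 holds the higher of the two numbers; compound 2 sits far lower, and that gap is beyond the scatter. For compound 3 the value given in this assay is a limit only, not a number (the limit of < 100000 nM in this assay, at which 1 of the 3 values shown sits).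

The step from compound 1 to compound 4 `Nc1cc(N)c2nc(-c3ccccc3)c(NCc3ccc(F)cc3)nc2c1` is a single change: (4-fluorobenzyl)amino in place of (4-fluorophenyl)sulfanyl on an aromatic carbon. Among the compounds with values here, no measured pair shows this exact step, so the expectation rests on the two numbers at hand. Compound 2, which also links its side group to the core through a nitrogen, gives 692 nM in this assay, well under the value of compound 1. Compound 4 is therefore expected to move downward, by a step of about an 11-fold lower number from compound 1 to compound 4 (1.05 log units; beyond the scatter), beyond the scatter. The estimate for compound 4 in this assay is 2500 nM, with a range from 600 nM to 10000 nM.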

Compound 4, concentration for 50% growth inhibition: 2510 nM
For compound 4 the middle estimate is 1.0-fold (0.00 log units) below the measured one; the measured number falls inside the stated range.
By their numbers in this assay, from the lowest: compound 2; then compound 4; then compound 1.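

In this assay, the aromatic carbon next to the ring nitrogen and ortho to a phenyl group is sensitive to its linking atoms: (4-fluorobenzyl)amino in place of (4-fluorophenyl)sulfanyl gives an 11-fold lower number from compound 1 to compound 4 (1.05 log units; beyond the scatter). The 4-fluorophenyl ring stays while the sulfur link gives way to an amino link with one added carbon, which gives the series a direct one-place reading at this position. No available measurement bears on what lies behind this step.

The nitrogen and the added carbon remain unseparated: a (4-fluorophenyl)amino or a (4-fluorobenzyl)sulfanyl group would tell them apart. Also open, from the compounds shown here alone, is what the benzyl ring tolerates, such as a carboxylic acid or a dimethylamino group, given that compound 4 at 2510 nM still holds a higher number than compound 2 at 692 nM.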